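The source may report more compounds than this note shows. Statements on the series, on what has been measured and on what is new or still open speak of the compounds shown alone.

Measured compounds

Compound 1: `COc1cc(CS(=O)(=O)c2nc3ccccc3[nH]2)ccc1OCc1nccc(OCC(F)(F)F)c1C` gives 1310 nM in a functional assay on cells (Erythrocyte, Homo sapiens); on this read-out lower numbers stand for stronger inhibition and higher numbers for weaker inhibition.
Compound 2: `COCCCOc1ccnc(COc2ccc(CS(=O)(=O)c3nc4cc(OC)ccc4[nH]3)cc2OC)c1C` gives 817 nM in this assay.

Of the two numbers, compound 2 stands lowest; compound 1 is the nearest, and the gap between the two is within the usual scatter, so no order between them can be claimed. For the measured compounds named here, the two compounds also differ in more than one place, and no single step between measured compounds is available, so nothing is known from these data about what the methoxy on the fused ring system contributes.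

Compound 3 is `COCCCOc1ccnc(COc2ccc(CS(=O)(=O)c3nc4ccccc4[nH]3)cc2OC)c1C`. It keeps the full side chain of compound 2 and differs from it only at the fused ring system: hydrogen in place of methoxy on an aromatic carbon.

Going by the values given here, with no measured step of this kind to go by, the expected step in this assay is small, most likely none beyond the scatter, with a slight lean toward a higher number. For compound 3 the estimate is 1000 nM, within 400 nM to 2500 nM, which corresponds to an expected step of a 1.2-fold higher number from compound 2 to compound 3 (0.09 log units; within the scatter).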

Compound 3, half-maximal inhibitory concentration: 355 nM
Compound 3: the middle estimate sits 2.8-fold (0.45 log units) above what was measured; the whole stated range lies above it.
By their numbers in this assay, from the lowest: compound 3; then compounds 2 and 1 (each within the scatter of the next).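

In this assay, hydrogen in place of methoxy on the aromatic carbon of the fused ring system gives a 2.3-fold lower number from compound 2 to compound 3 (0.36 log units; beyond the scatter), so this position now has its first readable step: with the side chain of compound 2 held fixed, 1H-benzimidazol-2-yl gives the lower number and 5-methoxy-1H-benzimidazol-2-yl is not required to reach this level. The side chain also becomes readable once the fused ring system is held unsubstituted: 2-methoxyethyl in place of trifluoromethyl gives a 3.7-fold lower number from compound 1 to compound 3 (0.57 log units; beyond the scatter), a separation that the earlier pair, differing in more than one place, could not provide. Nothing at hand accounts for either step.

Open, going by these compounds, is whether hydrogen in place of methoxy gives a similar step when the side chain carries the trifluoromethyl of compound 1. Also open, on these data alone, is how fluorine, an amine or a carboxylic acid on the same aromatic carbon would read, and whether a longer chain in place of 2-methoxyethyl would lower the number further.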